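Taking the bromo group off compound 3

A few compounds are considered here, and "the series" means these few. Any claim that something is new, unique, unknown or untested is made for them only; others in the source may bear on it.

Measured so far in a functional assay on MCF7 cells (Homo sapiens) for cytotoxicity, read by MTT assay, with a stated time of 72 h; a higher number here means a weaker inhibitor, a lower number a stronger inhibitor:
- compound 1 `O=C(N/N=C/c1ccc([N+](=O)[O-])cc1)Nc1cc2c(Nc3ccc(F)c(Cl)c3)ncnc2cc1O[C@H]1CCOC1`: "not active" (no number reported)
- compound 2 `COc1cc(/C=N/NC(=O)Nc2cc3c(Nc4ccc(F)c(Cl)c4)ncnc3cc2O[C@H]2CCOC2)cc(OC)c1OC`: 26500 nM
- compound 3 `O=C(N/N=C/c1ccc(O)c(Br)c1)Nc1cc2c(Nc3ccc(F)c(Cl)c3)ncnc2cc1O[C@H]1CCOC1`: 2690 nM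

Compound 3, at 2690 nM, holds the lower of the two numbers in the series. Compound 1 gave no number to compare with it. The unmeasured compound 4 `O=C(N/N=C/c1ccc(O)cc1)Nc1cc2c(Nc3ccc(F)c(Cl)c3)ncnc2cc1O[C@H]1CCOC1` differs from compound 3 by a single change: hydrogen in place of bromo on an aromatic carbon. In words, hydrogen stands in place of bromo on an aromatic carbon, turning 3-bromo-4-hydroxyphenyl into 4-hydroxyphenyl.

For the measured compounds named here, only one measured step bears on this: a 9.9-fold lower number from compound 2 to compound 3 (0.99 log units; beyond the scatter). Going by the values given here, it exchanges the whole 3,4,5-trimethoxyphenyl group for 3-bromo-4-hydroxyphenyl, so it does not isolate the bromo group, and no measured pair removes bromo alone. It does show that a change in this group can move the number beyond the scatter in this assay. Among the compounds with values here, compound 3 is also the only compound with a number this low, and it is the only one carrying bromo. A rise is therefore expected, smaller than the measured step. A single atom changes here. The expected step is a 2.2-fold higher number from compound 3 to compound 4 (0.35 log units; beyond the scatter). For compound 4 the estimated value is 6000 nM, with an expected range of 2000 nM to 20000 nM.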

Compound 4, half-maximal inhibitory concentration: 910 nM
Compound 4: middle estimate off by 6.6-fold (0.82 log units), on the high side; the whole stated range lies above it.
By their numbers in this assay, from the lowest: compound 4; then compound 3; then compound 2.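

In this assay, bromo on this aromatic carbon, ortho to a hydroxy group, proves unnecessary for the low number: hydrogen in its place gives a 3.0-fold lower number from compound 3 to compound 4 (0.47 log units; beyond the scatter), beyond the scatter and in the direction opposite to the rise that compound 3 alone had suggested. The advantage of the hydroxylated aryl group over 3,4,5-trimethoxyphenyl therefore does not depend on bromo, and 4-hydroxyphenyl now carries the largest step in the series, a 29-fold lower number from compound 2 to compound 4 (1.46 log units; beyond the scatter). No supporting data accompany these compounds to account for the direction of the bromo step.

Still open, going by these compounds, is whether this single position generally favours hydrogen, or whether fluoro, chloro, methoxy or an amine on the same aromatic carbon would also give a number on the low side of compound 3, and whether the hydroxy group itself contributes, which a carboxylic acid or an amine in its place would test. Compound 1, recorded as "not active" (no number reported), also remains unplaced on the numerical scale of this series.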